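Pyrazin-2-yl for Pyridin-2-yl: Expected Paw Edema Inhibition

This account rests on a few compounds, and the source may have more. Where it says the series, first, only, none or still open, it means among the compounds named here.

Of the compounds shown here, two with a shared core have been measured in a functional assay on the whole organism (strain Charles Foster albino) for inhibition, with Rattus norvegicus as the target, read by paw edema, with stated times of 30 min and 3 h, at a dose of 50 mg/kg by the oral route; on this read-out lower numbers stand for less inhibition and higher numbers for more inhibition at the one dose given (going by the name of the read-out). Compound 1 `COc1ccc(OC)c(C2CC(c3ccncc3)=NN2)c1` gives 13% in this assay. Compound 2 `COc1ccc(OC)c(-c2nc(-c3ccccn3)no2)c1` carries a different five-membered ring and a pyridin-2-yl group, and in this assay compound 2 gives 28%. On these two numbers compound 2 stands highest, and its gap to compound 1 lies beyond the scatter. Compound 3 `COc1ccc(OC)c(-c2nc(-c3cnccn3)no2)c1` is the compound not yet measured. It differs from compound 2 in one place: pyrazin-2-yl in place of pyridin-2-yl on an aromatic carbon. For the measured compounds named here, no pair of measured compounds shows this exchange, so its effect cannot be read from the numbers at hand. Compound 1 and compound 2 differ in more than one place, and their two values give no guide to a pyridin-2-yl to pyrazin-2-yl exchange on its own. A small step, in neither direction beyond the scatter, is therefore expected here: a number 3 percentage points lower from compound 2 to compound 3 (within the scatter) in this assay. For compound 3 the estimate in this assay is 25%, with a range from 10% to 40%.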

Compound 3, a percentage reported as inhibition, in the whole organism at one dose (the size of the read-out at that dose, not a potency): 11%
For compound 3 the middle estimate is 14 percentage points above the measured one, and the stated range covers the measured number.
By their numbers in this assay, from the lowest: compounds 3 and 1 (each within the scatter of the next); then compound 2.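

In this assay, the exchange of pyridin-2-yl for pyrazin-2-yl gives a reading at this position, on an aromatic carbon of a five-membered aromatic ring with 2 nitrogen and 1 oxygen: a number 17 percentage points lower from compound 2 to compound 3 (beyond the scatter). The two groups have the same count of heavy atoms, and neither has a hydrogen-bond donor or a net charge, yet the read-out at this one dose does not stay within the scatter when the six-membered aromatic ring goes from 1 hetero atom to 2 and the count of hydrogen-bond acceptors goes from 1 to 2, so even an exchange this small at this place can shift the number. No measurement at hand gives a reason for the lower number.

This single pair leaves open whether the step belongs to pyrazin-2-yl alone or would also appear with other groups at the same place, such as phenyl, pyridin-3-yl or an amine. It also leaves open whether the same exchange would give a step of this size on the core of compound 1, since a reading at one dose describes only the size of the effect at that dose and not a potency.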